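The compounds below may be only part of what the source reports. "The series", "measured", "known", "first", "only" and "open" are said of these compounds alone.

Measured so far:
Compound 1 `Cc1ccc(S(=O)(=O)Oc2ccc3c(c2C)[C@H](Cn2cc(-c4ccc(C(F)(F)F)cc4)nn2)[C@@]24CC(=O)[C@@](C)(CC[C@@H]32)C4)cc1` — > 20000 nM
Compound 2 `C=C1C[C@]23C[C@@]1(O)CC[C@@H]2c1cccc(C)c1[C@@H]3Cn1cc(-c2ccccc2)nn1` — > 20000 nM

In a functional assay on SW480 cells (Homo sapiens) for cytotoxicity, read by MTT assay, with a stated time of 4 days (on this read-out lower numbers stand for stronger inhibition and higher numbers for weaker inhibition), compound 1 gives > 20000 nM, which is a limit of the assay and not a number. Compound 2 `C=C1C[C@]23C[C@@]1(O)CC[C@@H]2c1cccc(C)c1[C@@H]3Cn1cc(-c2ccccc2)nn1` likewise returns in this assay only a limit, > 20000 nM. Where compound 1 stands is thus not fixed by a number: both readings sit at the limit of > 20000 nM in this assay, at which 2 of the 2 values shown sit, and no step between measured compounds can be laid out from them. Compound 1 and compound 2 cannot be placed in any order on what is shown.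

Compound 3 `Cc1ccc(S(=O)(=O)Oc2ccc3c(c2C)[C@H](Cn2cc(-c4ccc(Br)cc4)nn2)[C@@]24CC(=O)[C@@](C)(CC[C@@H]32)C4)cc1` is not yet measured in this assay. It differs from compound 1 by bromo in place of trifluoromethyl on an aromatic carbon. Among the measured compounds shown here, no measured step gives a size for this change. Because both measured readings sit at the limit of > 20000 nM in this assay, at which 2 of the 2 values shown sit, nothing shows any movement away from that limit within the series. The estimated step that the limit leaves unreadable from compound 1 to compound 3 in this assay is therefore set to none beyond the scatter. Compound 3 is expected to give about 25000 nM in this assay, within 8000 nM to 60000 nM, and most likely to be reported again only as a limit.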

Compound 3, half-maximal inhibitory concentration: > 20000 nM
Compound 3 gave a limit, no number; the forecaster's own chance of this, stated with the estimate: 80%; the middle value does not contradict the limit.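

In this assay compound 3 gives > 20000 nM, a limit of the assay and not a number. Compound 1 also stands at a limit, and no step can be read between compound 1 and compound 3 for bromo in place of trifluoromethyl. The compounds shown leave open which structure in this series, if any, would give a measurable value: the limit of > 20000 nM in this assay, at which 3 of the 3 values shown sit.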